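Moving One Methyl Group on a Sulfonamide Nitrogen's Aromatic Ring

This account rests on a few compounds, and the source may have more. Where it says the series, first, only, none or still open, it means among the compounds named here.

In a functional assay on Huh-7 cells (Homo sapiens) for inhibition, read by CCK-8 assay, with a stated time of 72 h (a lower number here means a stronger inhibitor, a higher number a weaker inhibitor), compound 1 `O=C(/C=C/c1cccnc1)NCCCCCCc1cccc(S(=O)(=O)Nc2ccccc2)c1` gives 2.82 nM and compound 2 `Cc1ccccc1NS(=O)(=O)c1cccc(CCCCCCNC(=O)/C=C/c2cccnc2)c1` gives 0.525 nM, so compound 2 holds the lower of the two numbers and is the stronger inhibitor of this pair. Compound 3 `Cc1cccc(NS(=O)(=O)c2cccc(CCCCCCNC(=O)/C=C/c3cccnc3)c2)c1` has the same atoms as compound 2, joined differently: 3-methylphenyl in place of 2-methylphenyl on a sulfonamide nitrogen.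

Within the data shown here, only one measured step bears on this change. Putting a methyl in place of a hydrogen on an aromatic carbon gave a 5.4-fold lower number from compound 1 to compound 2 (0.73 log units; beyond the scatter), a modest step beyond the scatter. Among the measured compounds shown here, no measured compound carries 3-methylphenyl, so the data cannot show how much of that improvement remains once the methyl moves. Some of it may well remain, so a small step towards a higher number in this assay is the reasonable expectation, landing between the two measured values.

The estimated step is a 2.3-fold higher number from compound 2 to compound 3 (0.36 log units; beyond the scatter). For compound 3, the expected value is 1.2 nM, with an estimated range from 0.4 nM to 3.5 nM.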

Compound 3, half-maximal inhibitory concentration: 13.2 nM
Compound 3: the middle estimate sits 11-fold (1.04 log units) below what was measured, and the stated range ends below it.
By their numbers in this assay, from the lowest: compound 2; then compound 1; then compound 3.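

In this assay, where the methyl sits on the ring matters as much as whether it is there: moving it from the 2-methylphenyl to the 3-methylphenyl arrangement, with no atom gained or lost, gives a 25-fold higher number from compound 2 to compound 3 (1.40 log units; beyond the scatter) and so undoes the gain seen earlier. Compared with the plain phenyl of compound 1, the relocated methyl gives a 4.7-fold higher number from compound 1 to compound 3 (0.67 log units; beyond the scatter) and so runs the opposite way to a 5.4-fold lower number from compound 1 to compound 2 (0.73 log units; beyond the scatter) as the earlier step, which means that adding a methyl to this ring is not a gain in itself, and its effect even changes direction with its place. Nothing available here explains why the two arrangements differ so sharply.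

As far as these compounds go, whether 4-methylphenyl would follow compound 2, compound 3 or neither remains open, since these three compounds cover only the plain ring and two methyl arrangements. It is also unknown whether the gain in compound 2 belongs to methyl specifically or would carry over to another group, such as the chlorine of 2-chlorophenyl or the longer ethyl of 2-ethylphenyl.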